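The source may hold more compounds than are shown below. What is called first, only, known or untested is meant among the compounds shown, and "the series" means these compounds.

Compound 3 `O=C(NC1CCCCC1)c1cc2ccc(OCc3ccccc3)cc2oc1=O` has the highest number of the three in an in vitro assay on BTI-TN-5B1-4 cells for inhibition of Amine oxidase [flavin-containing] B (Homo sapiens), read by fluorescence; on this read-out lower numbers stand for stronger inhibition and higher numbers for weaker inhibition: compound 3 gives 64500 nM, whereas compound 1 `O=C(NC1CCCCC1)c1cc2ccccc2oc1=O` gives 500 nM and compound 2 `CCc1ccc(NC(=O)c2cc3ccccc3oc2=O)cc1` gives 890 nM. Going by the values given here, the only single-point step measured, a 130-fold higher number from compound 1 to compound 3 (2.11 log units; beyond the scatter), concerns the benzyloxy group, not the amide substituent. Compound 4 `COc1ccc(NC(=O)c2cc3ccc(OCc4ccccc4)cc3oc2=O)cc1OC` keeps the benzyloxy group and differs from compound 3 by 3,4-dimethoxyphenyl in place of cyclohexyl on an amide-type nitrogen. Among the compounds with values here, no measured step addresses this change directly; the nearest guide is the pair of compound 1 and compound 2, which differ only at the amide nitrogen and whose two numbers lie within the usual scatter of each other. On that basis the step of a 1.3-fold lower number from compound 3 to compound 4 (0.11 log units; within the scatter) is expected to stay within or near the scatter in this assay, with no clear direction. Compound 4 is therefore estimated at 50000 nM, with a range of 15000 nM to 160000 nM.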

Compound 4, half-maximal inhibitory concentration: 4390 nM
The estimate for compound 4 lay 11-fold (1.06 log units) above the measured number; the measured number lies below the stated range.
By their numbers in this assay, from the lowest: compounds 1 and 2 (each within the scatter of the next); then compound 4; then compound 3.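

At the amide nitrogen, with the benzyloxy group present, the change to 3,4-dimethoxyphenyl from cyclohexyl gives a 15-fold lower number from compound 3 to compound 4 (1.17 log units; beyond the scatter) in this assay and so falls beyond the scatter. The amide substituent can therefore shift this series clearly, which the close numbers of compound 1 and compound 2 did not show. No available evidence accounts for the step.

Open, from the compounds shown here alone, is whether the aromatic ring or its methoxy groups carry the step, and whether it also holds without the benzyloxy group. Plain phenyl, or an amine or carboxylic acid in place of the methoxy groups, would separate these readings.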